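From 3-chlorobenzyl to 2-chlorobenzyl: what to expect

The source may hold more compounds than are shown below. What is called first, only, known or untested is meant among the compounds shown, and "the series" means these compounds.

Of the compounds shown here, three sharing one core have been measured in a functional assay on MCF7 cells (Homo sapiens) for cytotoxicity, read by MTT assay, with a stated time of 24 h; on this read-out lower numbers stand for stronger inhibition and higher numbers for weaker inhibition. There, compound 1 `COc1ccc(/C=C2\CN(C(=S)SCc3cn(Cc4ccccc4F)nn3)C/C(=C\c3ccc(OC)cc3)C2=O)cc1` gives 79400 nM. Compound 2 `COc1ccc(/C=C2\CN(C(=S)SCc3cn(Cc4ccc(F)cc4)nn3)C/C(=C\c3ccc(OC)cc3)C2=O)cc1` gives > 100000 nM, which is a limit of the assay and not a number. Compound 3 `COc1ccc(/C=C2\CN(C(=S)SCc3cn(Cc4cccc(Cl)c4)nn3)C/C(=C\c3ccc(OC)cc3)C2=O)cc1` gives 32000 nM, the lowest number of the three and thus the strongest inhibition so far.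

Compound 4 `COc1ccc(/C=C2\CN(C(=S)SCc3cn(Cc4ccccc4Cl)nn3)C/C(=C\c3ccc(OC)cc3)C2=O)cc1` has 2-chlorophenyl in place of 3-chlorophenyl on a saturated chain carbon bound to an aromatic nitrogen. Within the data shown here, no measured step makes exactly this change. The closest evidence is a 2.5-fold lower number from compound 1 to compound 3 (0.39 log units; beyond the scatter), where 3-chlorophenyl replaces 2-fluorophenyl. A second step, an at least 3.1-fold lower number from compound 2 to compound 3 (0.49 log units; beyond the scatter), replaces 4-fluorophenyl. Both also exchange the halogen, so they offer only a rough guide. Since compound 1, with its 2-fluorophenyl, gives the higher number 79400 nM, a small rise in this assay is expected, perhaps no larger than the scatter. The expected change is a 1.6-fold higher number from compound 3 to compound 4 (0.19 log units; within the scatter). Compound 4 is estimated at 50000 nM, within an expected range of 20000 nM to 100000 nM.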

Compound 4, half-maximal inhibitory concentration: > 100000 nM
Compound 4: only a limit was reported (the forecaster's own chance of this, stated with the estimate: 15%); at least 2.0-fold (0.30 log units) between middle value and limit.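

Going from 3-chlorophenyl to 2-chlorophenyl gives an at least 3.1-fold higher number from compound 3 to compound 4 (0.49 log units; beyond the scatter) in this assay. Every earlier step also exchanged the halogen, whereas this one keeps the same atoms and shows that the place of the chlorine alone can change the read-out, leaving compound 3 the strongest of the four. Keeping that place and putting chloro in place of fluoro gives an at least 1.2-fold higher number from compound 1 to compound 4 (0.10 log units; that floor lies within the scatter), a floor set by a limit of the assay, so this step does not tell the two halogens apart.

The step from compound 2 to compound 4 cannot be read, since both compounds rest on a limit: the limit of > 100000 nM in this assay, at which 2 of the 4 values shown sit. On these data alone, whether 3-fluorophenyl or 3-methoxyphenyl at this place would match 3-chlorophenyl stays open.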